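Triazole aryl exchange in a lignan lactone cytotoxicity series

This account rests on a few compounds, and the source may have more. Where it says the series, first, only, none or still open, it means among the compounds named here.

Compound 1 `CCN(CC)C(=O)CCC(=O)Oc1ccc(C[C@H]2C(=O)OC[C@@H]2Cc2ccc(OC)c(OC)c2)cc1OC` gives 213000 nM in an ADME assay on HeLa cells (Homo sapiens) for cytotoxicity, read by MTT assay (on this read-out higher numbers stand for weaker inhibition and lower numbers for stronger inhibition), and compound 3 `COc1ccc(C[C@H]2COC(=O)[C@@H]2Cc2ccc(OC(=O)CCC(=O)N3CCCCC3)c(OC)c2)cc1OC` gives 128000 nM. Among the compounds with values here, the only measured step, a 1.7-fold lower number from compound 1 to compound 3 (0.22 log units; within the scatter), does not involve the triazole region. Compound 2 `COc1ccc(C[C@H]2COC(=O)[C@@H]2Cc2ccc(OCc3cn(Cc4ccccc4F)nn3)c(OC)c2)cc1OC` reports only a limit in this assay, >= 600000 nM, as described in the limit of >= 600000 nM in this assay, at which 1 of the 3 values shown sits. Compound 4 `COc1ccc(-n2cc(COc3ccc(C[C@H]4C(=O)OC[C@@H]4Cc4ccc(OC)c(OC)c4)cc3OC)nn2)cc1` differs from compound 2 by 4-methoxyphenyl in place of 2-fluorobenzyl on an aromatic nitrogen. Within the data shown here, no measured step covers a change on the triazole nitrogen, so the expectation rests on compound 2 sitting at the limit. Compound 4 is expected to remain weakly cytotoxic, with an estimate of 600000 nM, between 250000 nM and 1200000 nM. The step expected is a number no higher from compound 2 to compound 4 (the limit leaves the size open), none beyond the scatter, with a limit again likely.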

Compound 4, half-maximal inhibitory concentration: >= 600000 nM
Compound 4: only a limit was reported; the forecaster's own chance of this, stated with the estimate: 60%; the middle value sits exactly at the limit.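

Compound 2 and compound 4 each report only a limit in this assay, so no step between them can be read: the limit of >= 600000 nM in this assay, at which 2 of the 4 values shown sit.

The compounds shown leave open whether 4-methoxyphenyl in place of 2-fluorobenzyl on the aromatic nitrogen changes the cytotoxicity at all.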